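Solubility After Exchanging the Group on the Amide-Type Nitrogen

The source may report more compounds than this note shows. Statements on the series, on what has been measured and on what is new or still open speak of the compounds shown alone.

In a physicochemical assay for solubility, at pH 6.8 (on this read-out higher numbers stand for higher solubility and lower numbers for lower solubility), compound 2 `CC(C)c1cc(NC(=O)n2ccc3cc(Oc4ncnc5c4CCNC5)ccc32)n[nH]1` gives 833000 nM and compound 3 `CC1(c2cc(NC(=O)n3ccc4cc(Oc5ncnc6c5CNC6)ccc43)n[nH]2)CC1` gives 489000 nM, and these two numbers lie within the usual scatter of each other. Compound 1 `Nc1cc(Oc2ccc3c(ccn3C(=O)Nc3cccc(C(F)(F)F)c3)c2)ncn1` stands at < 5000 nM, which is a limit and not a number.

The next compound to be measured is compound 4 `CC(C)(C)c1cc(NC(=O)n2ccc3cc(Oc4ncnc5c4CCNC5)ccc32)no1`. Relative to compound 2, it carries 5-(tert-butyl)-1,2-oxazol-3-yl in place of 5-isopropyl-1H-pyrazol-3-yl on an amide-type nitrogen. Going by the values given here, no measured pair of compounds isolates this exchange, so the expectation rests on the structural change and on one starting point. Compound 4 keeps the core of compound 2, which sets that starting point at 833000 nM. A modest downward move is expected, an estimated 3.3-fold lower number from compound 2 to compound 4 (0.52 log units; beyond the scatter), only a little beyond the scatter. For compound 4 the estimated value in this assay is 250000 nM with an expected range of 70000 nM to 700000 nM.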

Compound 4, solubility: 167000 nM
Beside the measured number, compound 4's estimate is 1.5-fold (0.18 log units) above it, within the range that was stated.
By their numbers in this assay, from the lowest: compound 4; then compounds 3 and 2 (each within the scatter of the next). At a limit, below all of these: compound 1.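

Going by these compounds alone, the step gives the first reading at this place, on an amide-type nitrogen whose other neighbour is the carbonyl carbon. In this assay, 5-(tert-butyl)-1,2-oxazol-3-yl in place of 5-isopropyl-1H-pyrazol-3-yl gives a 5.0-fold lower number from compound 2 to compound 4 (0.70 log units; beyond the scatter) and so shows that this read-out responds to the exchange, though only modestly. Nothing measured here bears on the cause of this move.

The exchange alters the ring's hetero atoms, its hydrogen-bond donor and acceptor count and the alkyl group all at once, so the compounds shown leave open which of these changes carries the step. Also open, on these data alone, is how a group bearing an amine or a carboxylic acid would read at this place.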